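A Small Chain Extension in the Cytotoxicity Series

This account rests on a few compounds, and the source may have more. Where it says the series, first, only, none or still open, it means among the compounds named here.

Of the compounds shown here, two sharing one core have been measured so far in an ADME assay on HepG2 cells (Homo sapiens) for cytotoxicity, read by XTT assay, with a stated time of 48 h; on this read-out lower numbers stand for higher toxicity in this test and higher numbers for lower toxicity in this test. Compound 1 `CCCCCCCCC[C@@H]1CC(O)=C(C(=O)CC)C(=O)O1` gives 50 ug/mL and compound 2 `CCCCCCCCC[C@@H]1CC(O)=C(C(=O)CCCC)C(=O)O1` gives 36 ug/mL. Going by the values given here, compound 2 therefore stands within the scatter of compound 1, the only other number available, and the two cannot be told apart. Compound 3 `CCCCCCCCC[C@@H]1CC(O)=C(C(=O)CCCCC)C(=O)O1` departs from compound 2 at a single place: methyl in place of hydrogen on a saturated chain carbon, four bonds along the chain from a carbonyl carbon. Among the compounds with values here, only one measured step bears on this change, namely ethyl in place of hydrogen on a saturated chain carbon, two bonds along the chain from a carbonyl carbon. That step is a 1.4-fold lower number from compound 1 to compound 2 (0.14 log units; within the scatter) and so lies within the scatter. With a single step of that size as a guide, no change beyond the scatter is expected in this assay, although a slight drift in the same direction remains possible. The estimate is a 1.2-fold lower number from compound 2 to compound 3 (0.06 log units; within the scatter), a step expected to stay within the scatter. For compound 3 the expected value is 31 ug/mL, with an estimated range from 16 ug/mL to 55 ug/mL.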

Compound 3, half-maximal cytotoxic concentration: 15 ug/mL
Estimate against measurement, compound 3: 2.1-fold (0.32 log units) above, outside the stated range (below it).
By their numbers in this assay, from the lowest: compound 3; then compounds 2 and 1 (each within the scatter of the next).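

In this assay, the methyl in place of hydrogen on a saturated chain carbon, four bonds along the chain from a carbonyl carbon, gives a 2.4-fold lower number from compound 2 to compound 3 (0.38 log units; beyond the scatter) and so shows that a change of a single carbon at this chain end can pass beyond the scatter, which the earlier step (a 1.4-fold lower number from compound 1 to compound 2 (0.14 log units; within the scatter)) did not do. The full change across the two steps gives a 3.3-fold lower number from compound 1 to compound 3 (0.52 log units; beyond the scatter) and also lies beyond the scatter. Compound 3 therefore has the lowest number of the three, which on this read-out stands for the highest toxicity in this test, and its steps to both compound 1 and compound 2 are beyond the scatter. Nothing available accounts for why the number falls at this step.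

As far as these compounds go, whether a longer chain at this place would carry the fall further, hold it or reverse it remains open. So does the outcome of a branched chain, or of a chain ending in an amine or a carboxylic acid, in this assay on the shared core.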